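The source may hold more compounds than are shown below. What is called first, only, known or untested is meant among the compounds shown, and "the series" means these compounds.

Of the compounds shown here, three have been measured in a functional assay on HeLa cells (Homo sapiens) for cytotoxicity, read by WST assay, with a stated time of 48 h; a higher number here means a weaker inhibitor, a lower number a stronger inhibitor. Compound 1 `O[C@@H](c1ccccc1)[C@H]1CO[C@H](c2ccccc2)[C@@H](C/C=C/c2ccccc2)C1` gives 6060 nM in this assay. Compound 3 `COc1cccc(/C=C/C[C@H]2C[C@@H]([C@@H](O)c3ccccc3)CO[C@@H]2c2ccccc2)c1` differs from it by hydrogen in place of methoxy on an aromatic carbon, and in this assay compound 3 gives 10900 nM. The step itself reads a 1.8-fold lower number from compound 3 to compound 1 (0.25 log units; within the scatter). Compound 2 `COc1ccc(/C=C/C[C@H]2C[C@@H]([C@@H](O)c3ccc(OC)c(OC)c3)CO[C@@H]2c2ccc(OC)c(OC)c2)cc1` gives 12200 nM in this assay. Its number is the highest of the three, but both compound 3 and compound 1 lie within the scatter of it, so no order among the three compounds can be read from these values. How the core of compound 2 differs from the core of compound 3 is not broken down here.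

Compound 4 `COc1ccc([C@H]2OC[C@H]([C@@H](O)c3ccc(OC)c(OC)c3)C[C@@H]2C/C=C/c2ccccc2)cc1OC` has not yet been measured. It derives from compound 2 by hydrogen in place of methoxy on an aromatic carbon. Going by the values given here, this is the same kind of change as the one from compound 3 to compound 1, not the same change: in compound 3 the methoxy sits meta to a large group, in compound 2 it sits para to a large group. The expected step in this assay is a 1.5-fold lower number from compound 2 to compound 4 (0.18 log units; within the scatter), set beside the measured one, because a 1.8-fold lower number from compound 3 to compound 1 (0.25 log units; within the scatter) stayed within the scatter and nothing measured here points to a larger effect of the same kind of change. Compound 4 is therefore expected to give about 8000 nM in this assay, with a likely range from 4000 nM to 16000 nM.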

Compound 4, half-maximal inhibitory concentration: 14800 nM
The estimate for compound 4 lay 1.9-fold (0.27 log units) below the measured number; the measured number falls inside the stated range.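

In this assay, hydrogen in place of methoxy on an aromatic carbon, para to a large group, gives a 1.2-fold higher number from compound 2 to compound 4 (0.08 log units; within the scatter). Set beside the step with the same kind of change on the other core, this new step does not differ from it beyond what two such steps can show: the same change on two cores in this assay, a 1.8-fold lower number (0.25 log units; within the scatter) from compound 3 to compound 1 and a 1.2-fold higher number (0.08 log units; within the scatter) from compound 2 to compound 4, 2.2-fold (0.34 log units) apart, within the scatter of two such steps. Going by these compounds alone, on both cores, then, this exchange leaves the number within the scatter, which shows no sign that the core governs the outcome of the change, but it neither establishes that the change has a real effect of a fixed size nor rules out a small influence of the core, as only two steps are available and neither can be told apart from repeated measurement.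

All the steps shown here exchange only methoxy and hydrogen on an aromatic ring, so it remains open whether another group at such a place, such as an amine, a carboxylic acid or a fluorine, would move the number beyond the scatter on either core. Also open, as far as these compounds go, is how the number would respond to a longer chain in place of 3-phenylprop-2-en-1-yl, or to a ketone in place of the hydroxyl.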